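This account rests on a few compounds, and the source may have more. Where it says the series, first, only, none or still open, it means among the compounds named here.

Compound 1 `C=C1C(=O)O[C@@H]2CC(C)=C([C@@H](C)CCCOC(C)=O)[C@@H](OC(=O)CCl)[C@H]12`: 28500 nM
Compound 2 `C=C1C(=O)O[C@@H]2CC(C)=C([C@@H](C)CCCOC(C)=O)[C@@H](OC(=O)CN(CC)CC)[C@H]12`: 10700 nM
Compound 3 `C=C1C(=O)O[C@@H]2CC(C)=C([C@@H](C)CCCOC(C)=O)[C@@H](OC(=O)c3ccccc3)[C@H]12`: 5190 nM

All three numbers come from a functional assay on HeLa cells (Homo sapiens) for cytotoxicity, read by sulforhodamine B assay, with a stated time of 72 h; on this read-out lower numbers stand for stronger inhibition and higher numbers for weaker inhibition. Compound 1 gives the highest number of the three. Its nearest neighbour is compound 2, with a 2.7-fold lower number from compound 1 to compound 2 (0.43 log units; beyond the scatter); the furthest is compound 3, with a 5.5-fold lower number from compound 1 to compound 3 (0.74 log units; beyond the scatter). Between the two esters that are not compound 1 the ordering is a 2.1-fold lower number from compound 2 to compound 3 (0.31 log units; beyond the scatter), so the aromatic ester sits lowest of the measured set.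

Compound 4 `C=C1C(=O)O[C@@H]2CC(C)=C([C@@H](C)CCCOC(C)=O)[C@@H](OC(=O)c3ccc(OC)cc3)[C@H]12` is varied at the same ester position as the other two: 4-methoxyphenyl in place of chloromethyl on a carbonyl carbon. The step that bears most directly on this change is a 5.5-fold lower number from compound 1 to compound 3 (0.74 log units; beyond the scatter), where an aromatic ring likewise replaced the chloromethyl group on the carbonyl carbon. The added methoxy group has no measured precedent in this set, so its contribution cannot be read from the numbers shown; the expectation rests on the phenyl step alone, and the two amine and phenyl steps suggest the change is in the modest range rather than large. For compound 4 a downward step of comparable size is expected, a 4.4-fold lower number from compound 1 to compound 4 (0.64 log units; beyond the scatter). Compound 4 is therefore estimated at 6500 nM in this assay, with a range from 2500 nM to 16000 nM.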

Compound 4, half-maximal inhibitory concentration: 8850 nM
Compound 4: middle estimate off by 1.4-fold (0.13 log units), on the low side; low and high end bracket the measured number.
By their numbers in this assay, from the lowest: compounds 3, 4 and 2 (each within the scatter of the next, the first and the last beyond it); then compound 1.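

In this assay, a second aromatic ester also sits below the chloromethyl ester, with a 3.2-fold lower number from compound 1 to compound 4 (0.51 log units; beyond the scatter), so the drop seen for compound 3 is not confined to the unsubstituted phenyl group. Methoxy in place of hydrogen on an aromatic carbon gives a 1.7-fold higher number from compound 3 to compound 4 (0.23 log units; within the scatter), which means the ring tolerates this substituent with no change that can be distinguished in these data, although a single substituent is thin ground for a rule about the ring. The comparison with the amino ester gives a 1.2-fold lower number from compound 2 to compound 4 (0.08 log units; within the scatter), so compound 4 cannot be separated from compound 2 even though compound 3 is separated from compound 2 by a small margin, and the advantage of an aromatic ester over the diethylamino ester therefore does not hold for both aromatic esters.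

As far as these compounds go, it remains open whether a nitrile or a fluorine on the phenyl ring, a longer saturated chain, or a carboxylic acid in the ester would move the number beyond the range spanned by these four compounds. No measurement is available that accounts for the differences among these esters.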